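A Hydantoin Pair Differing Only by a Para Chloro Group

This account rests on a few compounds, and the source may have more. Where it says the series, first, only, none or still open, it means among the compounds named here.

The account concerns three compounds built on one hydantoin core. Compound 1 `O=C1NC(=O)C(c2ccc(Cl)cc2)(C2CC2)N1` carries a chloro substituent on its phenyl ring; compound 3 `O=C1NC(=O)C(c2ccccc2)(C2CC2)N1` is the same core without it; and compound 2 `O=C(OCc1ccccc1)N1CCN(CN2C(=O)NC(c3ccccc3)(C3CC3)C2=O)CC1` bears a larger appendage on the ring nitrogen of the same core. Going by the values given here, in a functional assay on the whole organism (strain Sprague-Dawley albino) with Rattus norvegicus as the target, in the maximal electroshock model (a lower number here means that less compound is needed, a higher number that more compound is needed for the effect), compound 2 gives 10 mg/kg, the only number so far. Compound 1 stands nowhere on the numbers: in this assay compound 1 gives "not determined" (no result reported), so its place cannot be fixed. The change from compound 1 to compound 3 is hydrogen in place of chloro on an aromatic carbon. Among the compounds with values here, because compound 1 has no measured value, the size of this step in this assay cannot be read from data, and no step between measured compounds is available for comparison; the author expects at most a step within the usual scatter in either direction, and no larger change. Taking compound 2 with its 10 mg/kg as the nearest measured relative, compound 3 is expected to give about 12 mg/kg in this assay, with a likely range from 4 mg/kg to 40 mg/kg.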

Compound 3, dose for half-maximal effect in the Rattus norvegicus assay: 5.76 mg/kg
Compound 3: middle estimate off by 2.1-fold (0.32 log units), on the high side; low and high end bracket the measured number.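

Going by these compounds alone, compound 1 has no number in the Rattus norvegicus assay, so no step to compound 3 can be read there. In a physicochemical assay for lipophilicity (a lower number here means a more polar compound, a higher number a more lipophilic compound), compound 1 gives 2.63 and compound 3 gives 1.66 on the partition scale. The compounds shown leave open whether hydrogen in place of chloro changes the dose needed in the Rattus norvegicus assay at all.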